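The source may report more compounds than this note shows. Statements on the series, on what has been measured and on what is new or still open speak of the compounds shown alone.

Measured in a functional assay on the whole organism (strain Wistar) for inhibition, with Rattus norvegicus as the target, with a stated time of 4 h; on this read-out lower numbers stand for an effect already at smaller amounts and higher numbers for an effect only at larger amounts of compound:
- compound 1 `Cc1cc(=O)oc2cc(OCC(=O)NN)ccc12`: 8.05 nM
- compound 2 `Cc1cc(=O)oc2cc(OCc3nnc(S)o3)ccc12`: 7.85 nM

Compound 2 has a single measured neighbour, and a 1.0-fold lower number from compound 1 to compound 2 (0.01 log units; within the scatter) leaves the two values level. Compound 3 `Cc1cc(=O)oc2cc(OCc3nnc(S)s3)ccc12` is still unmeasured and carries 5-sulfanyl-1,3,4-thiadiazol-2-yl in place of 5-sulfanyl-1,3,4-oxadiazol-2-yl on a saturated chain carbon bound to an oxygen on an aromatic ring. For the measured compounds named here, that one step, made at the same place, is all that bears on compound 3, and no measured pair shows this exact ring exchange. No shift beyond the scatter is therefore expected in this assay, and the expected step is a 1.0-fold lower number from compound 2 to compound 3 (0.02 log units; within the scatter). Compound 3 is estimated at 7.5 nM, with an expected range of 4 nM to 14 nM.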

Compound 3, concentration for half-maximal effect: 7.95 nM
Beside the measured number, compound 3's estimate is 1.1-fold (0.03 log units) below it, within the range that was stated.
By their numbers in this assay, from the lowest: compounds 2, 3 and 1 (each within the scatter of the next).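

At this place, on a saturated chain carbon bound to an oxygen on an aromatic ring, this assay does not separate 5-sulfanyl-1,3,4-thiadiazol-2-yl from 5-sulfanyl-1,3,4-oxadiazol-2-yl, with a 1.0-fold higher number from compound 2 to compound 3 (0.01 log units; within the scatter). Exchanging aminocarbamoyl for the thiadiazole ring also leaves the values level, with a 1.0-fold lower number from compound 1 to compound 3 (0.01 log units; within the scatter), so all three groups now lie within the scatter of one another. Nothing available accounts for this result.

As far as these compounds go, whether any group at this place can move the value in this assay beyond the scatter remains open. A carboxylic acid, an amine or a longer chain would test this.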